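A few compounds are considered here, and "the series" means these few. Any claim that something is new, unique, unknown or untested is made for them only; others in the source may bear on it.

Among the compounds with values here, compound 3 `Cc1nn(-c2ncnc3nc[nH]c23)c2c1C(NC(=O)Cc1cccs1)CC(=O)N2` is one of three compounds measured in a functional assay on HEK293 cells for agonist activity at G-protein coupled receptor 39 (Homo sapiens), read by scintillation proximity assay and inositol phosphate accumulation, with a stated time of 75 min; on this read-out lower numbers stand for an effect already at smaller amounts and higher numbers for an effect only at larger amounts of compound. In this assay compound 3 gives 244 nM. Compound 1 `Cc1nn(-c2ncnc3nc[nH]c23)c2c1C(OCc1ccc(Cl)cc1Cl)CC(=O)N2` carries a different group on the same saturated ring carbon and gives 243 nM, which matches compound 3, as the comparison a 1.0-fold higher number from compound 1 to compound 3 (0.00 log units; within the scatter) shows. Compound 2 `Cc1cc(C)n(CCOC2CC(=O)Nc3c2c(C)nn3-c2ncnc3nc[nH]c23)n1` gives 2000 nM, and the move to compound 3 is an 8.2-fold lower number from compound 2 to compound 3 (0.91 log units; beyond the scatter). Compound 3 therefore sits with compound 1 at the lower pair of numbers, while compound 2 stands apart.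

Compound 4 `Cc1nn(-c2ncnc3nc[nH]c23)c2c1C(C(=O)N(C)c1nccs1)CC(=O)N2` differs from compound 3 at that same position: methyl(1,3-thiazol-2-yl)carbamoyl in place of (((thiophen-2-yl)methyl)carbonyl)amino on a saturated ring carbon. Within the data shown here, two measured steps bear on this kind of change. Both of them replaced the group on the same ring carbon: a 1.0-fold higher number from compound 1 to compound 3 (0.00 log units; within the scatter) left the number unchanged, and an 8.2-fold lower number from compound 2 to compound 3 (0.91 log units; beyond the scatter) was a modest move. The new group keeps one five-membered aromatic ring but loses the amide hydrogen, so a flat result or a modest rise in the number seems more likely than a large jump. The estimate for compound 4 is 500 nM, with a range from 150 nM to 3000 nM. This expected outcome corresponds to a 2.0-fold higher number from compound 3 to compound 4 (0.31 log units; beyond the scatter).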

Compound 4, half-maximal effective concentration: 3300 nM
The estimate for compound 4 lay 6.6-fold (0.82 log units) below the measured number; measured number outside the range, above it.
By their numbers in this assay, from the lowest: compounds 1 and 3 (each within the scatter of the next); then compounds 2 and 4 (each within the scatter of the next).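

In this assay, a 14-fold higher number from compound 3 to compound 4 (1.13 log units; beyond the scatter) and a 14-fold higher number from compound 1 to compound 4 (1.13 log units; beyond the scatter) show that this saturated ring carbon does not accept every group equally, even though compound 1 and compound 3 had matched despite carrying quite different groups there. The leaving and entering groups in the step to compound 4 each have 9 heavy atoms and one five-membered aromatic ring, so these counts alone do not set the number, and a 1.7-fold higher number from compound 2 to compound 4 (0.22 log units; within the scatter) places compound 4 level with compound 2 although their groups differ. No measurement here explains why this change has so large an effect.

On these data alone, what remains open is which part of the change matters, since the thiazole ring, the methyl on the amide nitrogen, the loss of the hydrogen-bond donor and the way the carbonyl and nitrogen are attached to the ring carbon all change in a single step. A (1,3-thiazol-2-yl)carbamoyl group without the methyl, or a methyl(thiophen-2-yl)carbamoyl group, would help to separate these parts, and how a carboxylic acid or an amine on the same ring carbon would read is also unknown.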